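The compounds below may be only part of what the source reports. "The series", "measured", "known", "first", "only" and "open" are said of these compounds alone.

Measured so far:
compound 1 `C#Cc1cc(C(F)(F)F)cc(C(F)(F)F)c1` — 0.3 h
compound 2 `O=C(CBr)c1cc(C(F)(F)F)cc(C(F)(F)F)c1` — < 0.017 h
compound 3 `FC(F)(F)c1cc(C2CO2)cc(C(F)(F)F)c1` — > 50 h

All three share one core and differ only in a single group on an aromatic carbon. Within the data shown here, in an ADME assay for pharmacokinetics, read by LC-MS, in phosphate buffer, with a stated time of 72 h, at pH 7.4, tested at 250 uM (on this read-out lower numbers stand for a shorter-lived compound and higher numbers for a longer-lived compound), compound 1 gives 0.3 h, and this is the only plain number among the three. For compound 2 the assay reports no number but a limit, (the limit of < 0.017 h in this assay, at which 1 of the 3 values shown sits). For compound 3 it likewise reports only a limit, (the limit of > 50 h in this assay, at which 1 of the 3 values shown sits). The step of an at least 17-fold lower number from compound 1 to compound 2 (1.24 log units; beyond the scatter) is a large shift toward a shorter-lived compound, while the step of an at least 160-fold higher number from compound 1 to compound 3 (2.22 log units; beyond the scatter) is a large shift toward a longer-lived one; the step of an at least 2900-fold higher number from compound 2 to compound 3 (3.46 log units; beyond the scatter) spans both ends.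

Compound 4 `Fc1cc(C(F)(F)F)cc(C(F)(F)F)c1` has not yet been measured. It differs from compound 1 in one place: fluoro in place of ethynyl on an aromatic carbon. Neither measured step swaps an ethynyl group for a fluoro group, so they frame the answer rather than give it: a single change at this one carbon has moved the half-life by large amounts in either direction. Compound 4 is expected to land toward the longer-lived side, with a 200-fold higher number from compound 1 to compound 4 (2.30 log units; beyond the scatter). The estimate for compound 4 is 60 h, with a range from 10 h to 500 h, and the assay may well report only a limit rather than a number.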

Compound 4, half-life: > 50 h
Compound 4: no number, only a limit; the forecaster's own chance of this, stated with the estimate: 65%; the middle value is on the limit's open side.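

In this assay compound 4 gives no number but a limit, the same kind of result as compound 3: the limit of > 50 h in this assay, at which 2 of the 4 values shown sit. Putting fluoro in place of ethynyl brings an at least 160-fold higher number from compound 1 to compound 4 (2.22 log units; beyond the scatter), and putting it in place of (bromomethyl)carbonyl brings an at least 2900-fold higher number from compound 2 to compound 4 (3.46 log units; beyond the scatter). This shows that the long-lived end is not reached by oxiran-2-yl alone: fluoro, with 1 heavy atom and no ring, also gets there, so this one aromatic carbon now carries two different groups at that end, while the step from compound 3 to compound 4 cannot be read from two limits.

Going by these compounds, how long compound 3 and compound 4 really last, and which of them lasts longer, stays open, since neither has a plain number on this scale. Also open, on these data alone, is how the half-life would respond to an amine, a carboxylic acid or a nitrile at this same carbon, or to a change in either of the two trifluoromethyl groups, and whether the large shifts seen here would hold on a different core.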